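Oxime in place of methyl on a shared core

The source may hold more compounds than are shown below. What is called first, only, known or untested is meant among the compounds shown, and "the series" means these compounds.

Measured compounds:
compound 2: `CCn1c(CNc2ccccc2)nnc1SCc1nc2cc(C)ccc2o1` — > 10000 nM
compound 1: `CC/C(=N/OC)c1ccc2oc(CSc3nnc(CNc4ccccc4)n3CC)nc2c1` — > 10000 nM

In an assay on isolated protein for inhibition of long-chain fatty acid transport protein 1 (Mus musculus) (a higher number here means a weaker inhibitor, a lower number a stronger inhibitor), compound 2 gives only a limit, > 10000 nM. Compound 1 likewise stops at a limit in this assay, > 10000 nM. Among the measured compounds shown here, the sole step between measured compounds, a step that the two limits leave unreadable from compound 1 to compound 2, cannot be read because of the limit of > 10000 nM in this assay, at which 2 of the 2 values shown sit. Compound 3, `CC/C(=N/O)c1ccc2oc(CSc3nnc(CNc4ccccc4)n3CC)nc2c1`, is not yet measured; it differs from compound 2 by a group of 5 heavy atoms (3 carbon, 1 nitrogen, 1 oxygen; no ring) in place of one carbon atom, on an aromatic carbon. For the measured compounds named here, no measured step gives a readable size that bears on this change, so there is nothing from which a shift beyond the scatter could be expected in either direction. Compound 3 is therefore expected to sit at the limit as well, and the step that the limit leaves unreadable from compound 2 to compound 3 is estimated to be unreadable in size. The estimate for compound 3 in this assay is 15000 nM, with a range from 5000 nM to 50000 nM.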

Compound 3, half-maximal inhibitory concentration: 200 nM
Estimate against measurement, compound 3: 75-fold (1.88 log units) above, outside the stated range (below it).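

In this assay, the oxime-bearing group on the aromatic carbon, in place of methyl, gives an at least 50-fold lower number from compound 2 to compound 3 (1.69 log units; beyond the scatter), so this position can carry a change that brings out measurable inhibition. The larger group alone does not account for this, as compound 1 carries the same chain with a methyl on the oxime oxygen, and hydrogen in place of that methyl gives an at least 50-fold lower number from compound 1 to compound 3 (1.69 log units; beyond the scatter). Both steps give only a minimum size, because neither starting compound has a value beyond a limit: the limit of > 10000 nM in this assay, at which 2 of the 3 values shown sit.

On these data alone, the true size of either step remains unknown. As far as these compounds go, it also remains open whether the oxime hydrogen is specifically required, and how a ketone, a primary amine or a carboxylic acid at this position would compare with the oxime.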